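The source may report more compounds than this note shows. Statements on the series, on what has been measured and on what is new or still open speak of the compounds shown alone.

In an ADME assay on MT4 cells (Homo sapiens) for cytotoxicity, read by MTT assay, with a stated time of 96 h (on this read-out lower numbers stand for higher toxicity in this test and higher numbers for lower toxicity in this test), three compounds sharing one core have been measured. Compound 1 `NS(=O)(=O)c1ccc(N2N=C(c3ccc(OCc4ccccc4)cc3)CC2c2ccccc2)cc1` gives > 100000 nM, which is a limit of the assay and not a number. Compound 2 `NS(=O)(=O)c1ccc(N2N=C(c3ccc(OCc4ccccc4)cc3)CC2c2ccc(F)cc2)cc1` gives > 100000 nM, which is also a limit. Within the data shown here, compound 3 `Cc1ccc(C2CC(c3ccc(OCc4ccccc4)cc3)=NN2c2ccc(S(N)(=O)=O)cc2)cc1` gives 35000 nM, the only actual number of the three.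

Compound 4 `NS(=O)(=O)c1ccc(N2N=C(c3ccc(OCc4ccccc4)cc3)CC2c2ccccc2F)cc1` differs from compound 3 in one place: 2-fluorophenyl in place of 4-methylphenyl on a saturated ring carbon. In words, 2-fluorophenyl stands in place of 4-methylphenyl on a saturated ring carbon.

Among the measured compounds shown here, two measured steps bear most directly on this change, as both add the methyl: an at least 2.8-fold lower number from compound 1 to compound 3 (0.45 log units; beyond the scatter) and an at least 2.8-fold lower number from compound 2 to compound 3 (0.45 log units; beyond the scatter). Both lie beyond the scatter. The fluoro step, a step that the two limits leave unreadable from compound 1 to compound 2, has limits at both ends and cannot be read. Compound 4 loses the methyl and carries a fluoro, as compound 2 does, so a move back toward higher numbers seems likely.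

The expected step is a 2.0-fold higher number from compound 3 to compound 4 (0.30 log units; within the scatter). For compound 4 the estimated value is 70000 nM, with an expected range from 35000 nM to 100000 nM.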

Compound 4, half-maximal cytotoxic concentration: 39000 nM
The estimate for compound 4 lay 1.8-fold (0.25 log units) above the measured number; the range from low to high includes it.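

In this assay, replacing 4-fluorophenyl with 2-fluorophenyl gives an at least 2.5-fold lower number from compound 2 to compound 4 (0.40 log units; beyond the scatter), so where the fluoro sits on this phenyl ring changes the read-out, which the earlier fluoro step, being unreadable, could not show. The same holds against the unsubstituted phenyl group, with an at least 2.5-fold lower number from compound 1 to compound 4 (0.40 log units; beyond the scatter), so a methyl is not needed for a measurable number on this saturated ring carbon. The swap of groups itself gives a 1.1-fold higher number from compound 3 to compound 4 (0.05 log units; within the scatter), so 2-fluorophenyl and 4-methylphenyl cannot be told apart in this test.

On these data alone, the true size of the two larger steps stays open, as each has a limit at one end: the limit of > 100000 nM in this assay, at which 2 of the 4 values shown sit. Also open is whether a carboxylic acid or an amine on this phenyl ring would give a measurable number too.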